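A few compounds are considered here, and "the series" means these few. Any claim that something is new, unique, unknown or untested is made for them only; others in the source may bear on it.

In a functional assay on DLD-1 cells (Homo sapiens) for cytotoxicity, read by WST assay, with a stated time of 72 h (on this read-out higher numbers stand for weaker inhibition and lower numbers for stronger inhibition), compound 1 `CCN(CC)CCCOc1cc2ncnc(Nc3nc4ccc(C(=O)Nc5c(C)cccc5Cl)cc4s3)c2cc1OC` gives 11700 nM. Compound 2 `COc1cc2c(Nc3nc4ccc(C(=O)Nc5c(C)cccc5C)cc4s3)ncnc2cc1OCCCN1CCC(C)CC1` sits at the limit of > 100000 nM in this assay, at which 1 of the 2 values shown sits, so in this assay compound 2 shows > 100000 nM, a limit rather than a number. Compound 3 `COc1cc2c(Nc3nc4ccc(C(=O)Nc5c(C)cccc5Cl)cc4s3)ncnc2cc1OCCCN1CCC(C)CC1` differs from compound 2 only by chloro in place of methyl on an aromatic carbon, which gives it the same 2-chloro-6-methylphenyl group as compound 1. Because compound 1 gives a measurable 11700 nM, compound 3 is expected to show a step of an at least 3.3-fold lower number from compound 2 to compound 3 (0.52 log units; beyond the scatter) toward stronger inhibition. Compound 3 is estimated at 30000 nM, with a range from 8000 nM to 100000 nM.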

Compound 3, half-maximal inhibitory concentration: 11300 nM
For compound 3 the middle estimate is 2.7-fold (0.42 log units) above the measured one; low and high end bracket the measured number.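

In this assay, chloro in place of methyl on the 2,6-dimethylphenyl group gives an at least 8.8-fold lower number from compound 2 to compound 3 (0.94 log units; beyond the scatter), so one atom on this ring separates a measurable compound from an unmeasured one. Compound 2 stands at a limit, not a number: the limit of > 100000 nM in this assay, at which 1 of the 3 values shown sits. With the 2-chloro-6-methylphenyl group present, 4-methylpiperidin-1-yl in place of diethylamino gives a 1.0-fold lower number from compound 1 to compound 3 (0.02 log units; within the scatter), so the two compounds cannot be told apart here.

From the compounds shown here alone, whether fluoro or bromo in place of that chloro would serve equally remains open. So does whether morpholin-4-yl at the chain end would match these two amines.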